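A few compounds are considered here, and "the series" means these few. Any claim that something is new, unique, unknown or untested is made for them only; others in the source may bear on it.

Compound 1 `COc1ncc(-c2nc(C(F)(F)F)sc2N2CCN(C(=O)Cn3cnc4cccnc43)[C@H](C)C2)cn1` is tested in a functional assay on U2OS cells for antagonist activity at C-X-C chemokine receptor type 3 (Homo sapiens), read by beta-arrestin recruitment (a higher number here means a weaker inhibitor, a lower number a stronger inhibitor), where compound 1 gives 177 nM. Compound 2 `CCOc1ncc(-c2nc(C(F)(F)F)sc2N2CCN(C(=O)Cn3cnc4cccnc43)[C@H](C)C2)cn1` differs from it by methyl in place of hydrogen on a saturated chain carbon bound to an oxygen on an aromatic ring, and in this assay compound 2 gives 20 nM, a step of an 8.9-fold lower number from compound 1 to compound 2 (0.95 log units; beyond the scatter). Compound 3 `Cc1ncc(-c2nc(C(F)(F)F)sc2N2CCN(C(=O)Cn3nc(C)nc3C)[C@H](C)C2)cn1` carries a different core; the difference between the two cores is not broken down here. In this assay compound 3 gives 578 nM. Compound 4 `CCc1ncc(-c2nc(C(F)(F)F)sc2N2CCN(C(=O)Cn3nc(C)nc3C)[C@H](C)C2)cn1` differs from compound 3 by methyl in place of hydrogen on a saturated chain carbon bound to an aromatic carbon. Going by the values given here, this is the same kind of change as the one from compound 1 to compound 2, but not the same: there the carbon was bound to an oxygen on an aromatic ring, here it is bound to an aromatic carbon. A smaller gain is expected, a step of a 3.0-fold lower number from compound 3 to compound 4 (0.48 log units; beyond the scatter). That expectation rests on an 8.9-fold lower number from compound 1 to compound 2 (0.95 log units; beyond the scatter) having been made at a different place and on a different core. Compound 4 is therefore expected to give about 190 nM, between 60 nM and 600 nM.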

Compound 4, half-maximal inhibitory concentration: 1430 nM
The estimate for compound 4 lay 7.5-fold (0.88 log units) below the measured number, outside the stated range (above it).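

In this assay the same added methyl gave a 2.5-fold higher number from compound 3 to compound 4 (0.39 log units; beyond the scatter), so the gain seen on the core of compound 1 did not carry over to the core of compound 3. The two steps run in opposite directions and lie far apart: the same change on two cores in this assay, an 8.9-fold lower number (0.95 log units; beyond the scatter) from compound 1 to compound 2 and a 2.5-fold higher number (0.39 log units; beyond the scatter) from compound 3 to compound 4, 22-fold (1.34 log units) apart, beyond the scatter of two such steps This shows that the effect of this change cannot be assumed to transfer within this series, but it does not show why: the two pairs differ both in their core and in the place of the change, and each step rests on a single pair.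

Going by these compounds, it remains open how a longer chain such as propyl, or an amine, would compare with the ethyl of 2-ethylpyrimidin-5-yl. Also open, on these data alone, is whether core or place decides the direction of the step.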